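Extending a Side Chain in a Weakly Cytotoxic Series

The source may hold more compounds than are shown below. What is called first, only, known or untested is meant among the compounds shown, and "the series" means these compounds.

Measured in a functional assay on MCF7 cells (Homo sapiens) for cytotoxicity, read by sulforhodamine B assay, with a stated time of 48 h; on this read-out higher numbers stand for weaker inhibition and lower numbers for stronger inhibition:
Compound 1 `Cc1ccccc1NS(=O)(=O)c1cccc(NC(=O)NCCCCl)c1` gives 52000 nM.
Compound 2 `CCc1ccccc1NS(=O)(=O)c1cccc(NC(=O)NCCCCl)c1` gives 43000 nM.
Compound 3 `CCc1ccccc1NS(=O)(=O)c1ccc(NC(=O)NCCCCl)cc1` gives > 200000 nM, which is a limit of the assay and not a number.

Compound 2 differs from compound 1 by methyl in place of hydrogen on a saturated chain carbon bound to an aromatic carbon, and this step is a 1.2-fold lower number from compound 1 to compound 2 (0.08 log units; within the scatter). Compound 3 differs from compound 1 in its core, and that difference is not broken down here. Compound 3 sits at the limit of > 200000 nM in this assay, at which 1 of the 3 values shown sits.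

Compound 4 `CCCc1ccccc1NS(=O)(=O)c1ccc(NC(=O)NCCCCl)cc1` is not yet measured in this assay. It differs from compound 3 by methyl in place of hydrogen on a saturated chain carbon, two bonds along the chain from an aromatic carbon. This is the same kind of change as from compound 1 to compound 2, not the same one: there the place was on a saturated chain carbon bound to an aromatic carbon, here it is two bonds along the chain from an aromatic carbon. The expected step is a step that the limit leaves unreadable from compound 3 to compound 4, resting on the earlier step of a 1.2-fold lower number from compound 1 to compound 2 (0.08 log units; within the scatter) lying within the scatter. Compound 4 is therefore estimated at 250000 nM, quite possibly again reported only as a limit.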

Compound 4, half-maximal inhibitory concentration: 35000 nM
Compound 4: middle estimate off by 7.1-fold (0.85 log units), on the high side; measured number outside the range, below it.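

In this assay, the methyl that turns 2-ethylphenyl into 2-propylphenyl gives an at least 5.7-fold lower number from compound 3 to compound 4 (0.75 log units; beyond the scatter). Going by these compounds, a change of this kind therefore does not carry over at the same size from one core to the other: the same change on two cores in this assay, a 1.2-fold lower number (0.08 log units; within the scatter) from compound 1 to compound 2 and an at least 5.7-fold lower number (0.75 log units; beyond the scatter) from compound 3 to compound 4, at least 4.7-fold (0.67 log units) apart, beyond the scatter of two such steps Compound 3 gives > 200000 nM, which is a limit of the assay and not a number, so the full size of this step stays unknown, and these two pairs do not show whether the core or the place of the methyl sets the gap.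

On these data alone, it remains open whether a butyl group in place of the propyl group of compound 4 would lower the number further. As far as these compounds go, it is also open what the 2-propylphenyl group would give on the core of compound 1.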